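Adding a second methoxy group on a shared core

This account rests on a few compounds, and the source may have more. Where it says the series, first, only, none or still open, it means among the compounds named here.

Two measured compounds share one core and differ only in the group attached to a carbon with a double bond to nitrogen. Compound 1 `O=C(N/N=C/c1ccc(O)c(O)c1)c1cccnc1Nc1cccc(C(F)(F)F)c1` carries 3,4-dihydroxyphenyl there; in a functional assay on the whole organism (strain Wistar) for inhibition, with Rattus norvegicus as the target, read by paw edema, with a stated time of 4 h, at a dose of 10 mg/kg by the intraperitoneal route (on this read-out higher numbers stand for more inhibition at the one dose given (going by the name of the read-out) and lower numbers for less inhibition), compound 1 gives 21.1%. Compound 2 `COc1ccc(/C=N/NC(=O)c2cccnc2Nc2cccc(C(F)(F)F)c2)cc1` carries 4-methoxyphenyl instead; in this assay compound 2 gives 14%. The step of a number 7.1 percentage points lower from compound 1 to compound 2 (within the scatter) is the only one on record, and because it lies within the scatter, compound 2 cannot be set apart from compound 1 on these numbers.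

Compound 3 `COc1ccc(/C=N/NC(=O)c2cccnc2Nc2cccc(C(F)(F)F)c2)c(OC)c1` has not been measured. (methoxy in place of hydrogen on an aromatic carbon). Going by the values given here, no measured step adds a methoxy group to a ring that already holds one; the single known step exchanged the whole aryl group and still moved the number by only a number 7.1 percentage points lower from compound 1 to compound 2 (within the scatter). Among the compounds with values here, with that as the only guide, the expected step of a number 1 percentage points higher from compound 2 to compound 3 (within the scatter) is none beyond the scatter. Compound 3 is therefore estimated at 15% in this assay, with a likely range from 5% to 28%.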

Compound 3, a percentage reported as inhibition, in the whole organism at one dose (the size of the read-out at that dose, not a potency): 19.8%
Estimate against measurement, compound 3: 4.8 percentage points below; low and high end bracket the measured number.
By their numbers in this assay, from the lowest: compounds 2, 3 and 1 (each within the scatter of the next).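

Going by these compounds alone, this is the first measured step that changes a single spot on the aromatic ring rather than the whole aryl group. Placing a methoxy group on an aromatic carbon ortho to a large group and meta to the methoxy group already there gives, in this assay, a number 5.8 percentage points higher from compound 2 to compound 3 (within the scatter), so on these numbers this position takes the added methoxy group without a change that can be told apart from hydrogen. Exchanging 3,4-dihydroxyphenyl for 2,4-dimethoxyphenyl gives a number 1.3 percentage points lower from compound 1 to compound 3 (within the scatter), so the 3,4-dihydroxyphenyl, 4-methoxyphenyl and 2,4-dimethoxyphenyl compounds all stand within the scatter of one another, and nothing available here bears on why their numbers lie so close together.

Still open, going by these compounds, is whether a different kind of group on this ring, such as an amine or a carboxylic acid, would give a step beyond the scatter, and whether the methoxy group ortho to a large group would read the same without the other methoxy group. Also open, on these data alone, is how the three compounds compare at other doses: a percentage at one dose is not a potency.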